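Methyl in place of phenyl on the ring amide nitrogen

A few compounds are considered here, and "the series" means these few. Any claim that something is new, unique, unknown or untested is made for them only; others in the source may bear on it.

Measured so far:
compound 1 `O=C1NC(=O)N(Cc2ccccc2)/C1=C/c1ccc(O)cc1`: 41%
compound 2 `O=C1NC(=O)N(c2ccccc2)/C1=C/c1ccccc1`: 18%
compound 3 `O=C1NC(=O)N(c2ccccc2)/C1=C\c1ccccc1`: 26%

In a functional assay on A549 cells (Homo sapiens) for antiproliferative activity, read by trypan blue exclusion, with a stated time of 72 h, tested at 20 uM (on this read-out higher numbers stand for more inhibition at the one concentration tested (going by the name of the read-out) and lower numbers for less inhibition), compound 3 gives 26%, the second highest of the three numbers. For the measured compounds named here, compound 2 sits within the scatter of it, the only measured step being a number 8 percentage points higher from compound 2 to compound 3 (within the scatter), which rests on (the fact that compounds 2 and 3 differ only in the configuration as drawn). Compound 1 gives the higher number, beyond the scatter.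

Compound 4 `CN1C(=O)NC(=O)/C1=C/c1ccccc1` is not yet measured. It differs from compound 3 by methyl in place of phenyl on an amide-type nitrogen in a ring. Going by the values given here, no measured step changes the group on that ring nitrogen; the one measured step concerns only the double-bond geometry and gives no guide here. Without a comparable step, no change beyond the scatter is expected, so compound 4 is estimated at 22%, between 5% and 45%, which is an expected step of a number 4 percentage points lower from compound 3 to compound 4 (within the scatter).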

Compound 4, a percentage reported as inhibition, at one concentration (the size of the read-out at that concentration, not a potency): 16%
For compound 4 the middle estimate is 6 percentage points above the measured one, within the range that was stated.
By their numbers in this assay, from the lowest: compounds 4, 2 and 3 (each within the scatter of the next); then compound 1.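

Methyl in place of phenyl on the ring nitrogen gives a number 10 percentage points lower from compound 3 to compound 4 (within the scatter) in this assay and so this position gives up the six-membered aromatic ring without a change beyond the scatter. On these two compounds, phenyl is not required on that nitrogen to hold the number at this level. No measured evidence bears on a cause for this step.

Still open, on these data alone, is whether an ethyl group, a longer chain, an amine or a carboxylic acid on that ring nitrogen would move the number beyond the scatter. Also open, as far as these compounds go, is how the amide hydrogen at that place would compare.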